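The source may hold more compounds than are shown below. What is called first, only, known or untested is meant among the compounds shown, and "the series" means these compounds.

Measured in a functional assay on MDA-MB-231 cells (Homo sapiens) for inhibition, read by MTT assay, with stated times of 18 h and 4 h; on this read-out lower numbers stand for stronger inhibition and higher numbers for weaker inhibition:
compound 1 `CCCCCCCCCCOP(=O)(O)OCCSC(=S)N1CCCCCC1`: 11400 nM
compound 2 `CCCOP(=O)(O)OCCSC(=S)N1CCCCC1`: 68000 nM
compound 3 `CCCCCCCCCCOP(=O)(O)OCCSC(=S)N1CCCC1`: 67000 nM

In this assay, compound 3 gives 67000 nM, which lies within the scatter of compound 2 at 68000 nM. Compound 1 stands clearly apart from compound 3, and the measured change is a 5.9-fold higher number from compound 1 to compound 3 (0.77 log units; beyond the scatter). The next compound is compound 4 `CCCCCCCCCCOP(=O)(O)OCCSC(=S)N1CCCCC1`, which has piperidin-1-yl in place of pyrrolidin-1-yl on a thiocarbonyl carbon.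

Among the measured compounds shown here, only one measured step bears directly on this change. It is a 5.9-fold higher number from compound 1 to compound 3 (0.77 log units; beyond the scatter), a modest step beyond the scatter, made by exchanging azepan-1-yl for pyrrolidin-1-yl at the same carbon. Compound 4 keeps the chain of compound 1 and compound 3, and its group lies in size between their two groups. For the measured compounds named here, compound 2 carries the same piperidin-1-yl group on a shorter chain and gives 68000 nM, but no measured step isolates the effect of that chain. A lower number than that of compound 3 is therefore expected, covering part of the measured step. The expected step is a 2.5-fold lower number from compound 3 to compound 4 (0.39 log units; beyond the scatter). For compound 4 the estimated value is 27000 nM, with an expected range from 10000 nM to 65000 nM.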

Compound 4, half-maximal inhibitory concentration: 24600 nM
Compound 4: the middle estimate sits 1.1-fold (0.04 log units) above what was measured; the range from low to high includes it.
By their numbers in this assay, from the lowest: compound 1; then compound 4; then compounds 3 and 2 (each within the scatter of the next).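

In this assay the piperidin-1-yl group on the thiocarbonyl carbon sets compound 4 apart from both compounds that share its chain (a 2.7-fold lower number from compound 3 to compound 4 (0.44 log units; beyond the scatter) and a 2.2-fold higher number from compound 1 to compound 4 (0.33 log units; beyond the scatter)), so across these three compounds the numbers fall in the order pyrrolidin-1-yl, piperidin-1-yl, azepan-1-yl, and none of the three goes against that order. Among the compounds shown here, compound 4 also supplies the first step that changes the chain alone while piperidin-1-yl stays in place (a 2.8-fold lower number from compound 2 to compound 4 (0.44 log units; beyond the scatter)), for heptyl in place of hydrogen on a saturated chain carbon, so both the ring and the chain are now seen to shift the number in this assay on their own. Nothing measured here gives a reason for either step.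

On these data alone, whether the order carries on to azocan-1-yl, or survives an oxygen in the ring as in morpholin-4-yl, remains open. Also open, as far as these compounds go, are whether a chain longer than that of compound 4 would lower the number further and whether the ring steps seen on the longer chain would hold on the short chain of compound 2.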